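The source may hold more compounds than are shown below. What is called first, only, known or untested is meant among the compounds shown, and "the series" means these compounds.

Compound 1, `COc1cc(/C=C/C(=O)C2=C(/C=C/c3ccc(O)c(OC)c3)NC(=O)NC2c2ccc(N(C)C)cc2)ccc1O`: 17.9%
Compound 2, `COc1cc(/C=C/C(=O)C2=C(/C=C/c3ccc(O)c(OC)c3)NC(=S)NC2c2ccc(C)cc2)ccc1O`: 15.5%

In a functional assay, with a stated time of 20 min, tested at 2 uM (a lower number here means a weaker effect, a higher number a stronger effect of the compound at the concentration tested), compound 2 gives 15.5%, which puts it at the bottom of the two numbers shown, while compound 1 gives 17.9%. The gap between the two lies within the usual scatter of this measurement, so neither compound can be said to act more strongly than the other; both sit together at a weak level of effect.

Compound 3, `COc1cc(/C=C/C(=O)C2=C(/C=C/c3ccc(O)c(OC)c3)NC(=S)NC2c2ccccc2Cl)ccc1O`, has not yet been measured. It differs from compound 2 in one place only: 2-chlorophenyl in place of 4-methylphenyl on a saturated ring carbon. The rest of the molecule, the shared core and the two groups carrying hydroxyl and methoxy substituents, stays as in compound 2.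

Among the measured compounds shown here, no step between two measured compounds is known that would show how an exchange of this kind moves the read-out, so there is no basis for expecting a shift beyond the scatter in either direction. With both measured compounds so close together, compound 3 is expected to land near them. The expected step is a number 0.5 percentage points higher from compound 2 to compound 3 (within the scatter), small and in no particular direction. For compound 3 the expected value in this assay is 16%, with a range from 5% to 30%.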

Compound 3, a percentage reported as activity, at one concentration (the size of the read-out at that concentration, not a potency): 16.2%
The estimate for compound 3 lay 0.2 percentage points below the measured number, and the stated range covers the measured number.
By their numbers in this assay, from the lowest: compounds 2, 3 and 1 (each within the scatter of the next).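

Among the compounds shown here, this is the first readable step at this position: in this assay, 2-chlorophenyl in place of 4-methylphenyl on the saturated ring carbon gives a number 0.7 percentage points higher from compound 2 to compound 3 (within the scatter), so this exchange leaves the read-out unchanged within the scatter. Both groups are six-membered aromatic rings of carbon carrying one substituent, and the exchange alters both the kind of substituent and its place on that ring, yet the combined change produces no readable shift at the concentration tested. Nothing measured here bears on why the read-out holds steady.

For the compounds shown here, the single step cannot separate those two parts of the exchange, and the pair 4-chlorophenyl and 2-methylphenyl would be needed to show whether each alone also leaves the number within the scatter. From the compounds shown here alone, it also remains open whether a more different group at this ring carbon, such as a phenyl ring carrying a carboxylic acid or a longer carbon chain in place of the aromatic ring, would move the read-out beyond the scatter in either direction.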